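Amide to urea on the shared core: compound 4

The compounds below may be only part of what the source reports. "The series", "measured", "known", "first", "only" and "open" are said of these compounds alone.

Compound 1 `COc1cc(-c2nn(-c3cccc(NC(=O)c4cccc(C(F)(F)F)c4)c3)cc2-c2ccncc2)ccc1Cl` is the starting point. In a functional assay on SK-OV-3 cells (Homo sapiens) for inhibition, read by sulforhodamine B assay, with a stated time of 48 h (on this read-out higher numbers stand for weaker inhibition of growth and lower numbers for stronger inhibition of growth), compound 1 gives 2290 nM. Of the three numbers shown it is the largest, yet neither gap reaches beyond the usual scatter: compound 2 `COc1cc(-c2nn(-c3cccc(NC(=O)Nc4ccc(Cl)c(Cl)c4)c3)cc2-c2ccncc2)ccc1Cl` gives 1930 nM, and compound 3 `O=C(Nc1cccc(-n2cc(-c3ccncc3)c(-c3ccc(Cl)c(O)c3)n2)c1)Nc1cc(C(F)(F)F)cc(C(F)(F)F)c1`, which also carries a hydroxyl in place of the methoxy group, gives 1350 nM.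

The change to compound 4 `COc1cc(-c2nn(-c3cccc(NC(=O)Nc4ccc(Cl)c(C(F)(F)F)c4)c3)cc2-c2ccncc2)ccc1Cl` is (4-chloro-3-(trifluoromethyl)phenyl)amino in place of 3-(trifluoromethyl)phenyl on a carbonyl carbon, an amide becoming a urea with a chlorine added to the ring. Among the measured compounds shown here, one measured step bears on this: the same amide-to-urea swap, with a different ring, gave a 1.2-fold lower number from compound 1 to compound 2 (0.07 log units; within the scatter). Compound 3, a urea as well, shows only a modestly smaller number than compound 1, and two places differ there. Neither observation points to a step beyond the scatter.

Compound 4 is therefore expected to sit close to compound 1, with an estimated step of a 1.3-fold lower number from compound 1 to compound 4 (0.10 log units; within the scatter). The estimate for compound 4 in this assay is 1800 nM, in a range from 900 nM to 3600 nM.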

Compound 4, concentration for 50% growth inhibition: 1450 nM
The estimate for compound 4 lay 1.2-fold (0.09 log units) above the measured number, within the range that was stated.
By their numbers in this assay, from the lowest: compounds 3, 4, 2 and 1 (each within the scatter of the next).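

In this assay, putting (4-chloro-3-(trifluoromethyl)phenyl)amino in place of 3-(trifluoromethyl)phenyl on the carbonyl carbon gives a 1.6-fold lower number from compound 1 to compound 4 (0.20 log units; within the scatter), so a second urea with a different ring also stays level with the amide. Compound 4 also supplies a change on the ring alone, trifluoromethyl in place of chloro on an aromatic carbon, which gives a 1.3-fold lower number from compound 2 to compound 4 (0.12 log units; within the scatter), so the urea series shows no real shift from this swap either. No measurement here bears on what lies behind these small steps.

Open, from the compounds shown here alone, is whether an amine, a carboxylic acid or a plain alkyl chain at this end of the urea would move the number beyond the scatter. The hydroxyl of compound 3 also remains unresolved, as compound 3 differs from the other compounds in more than one place.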